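Swapping trifluoromethyl for chloro on a benzyl group

The compounds below may be only part of what the source reports. "The series", "measured", "known", "first", "only" and "open" are said of these compounds alone.

Of the compounds shown here, three have been measured in an ADME assay on microsomes from liver (Homo sapiens) for metabolic stability, read by LC-MS, using NADPH, tested at 5 uM; a lower number here means that the compound disappears faster, a higher number that the compound lasts longer. Compound 2 `Cc1cc(-c2ccccc2)n(/C(N)=N/S(=O)(=O)c2cc(C)c(Cl)cc2SCc2ccccc2C(F)(F)F)n1` gives 0.306 h, the highest of the three numbers; the nearest is compound 1 `Cc1cc(S(=O)(=O)/N=C(\N)n2nccc2-c2ccccc2)c(SCc2ccccc2Cl)cc1Cl` with 0.226 h, and the furthest is compound 3 `Cc1cc(S(=O)(=O)/N=C(\N)n2nccc2-c2ccccc2)c(SCc2ccc(C(F)(F)F)cc2)cc1Cl` with 0.176 h, both gaps within the scatter. Compound 4 `Cc1cc(-c2ccccc2)n(/C(N)=N/S(=O)(=O)c2cc(C)c(Cl)cc2SCc2ccccc2Cl)n1` has not yet been measured. It differs from compound 2 by chloro in place of trifluoromethyl on an aromatic carbon, the group sitting on an aromatic carbon of a six-membered aromatic ring of carbon only, ortho to a large group. Within the data shown here, no measured step makes exactly this change. The nearest guide is a 1.3-fold lower number from compound 1 to compound 3 (0.11 log units; within the scatter), a swap of the same pair of groups on the same benzyl ring at a different position, which stayed within the scatter. Compound 1 carries the same 2-chlorobenzyl group as compound 4 and sits within the scatter of compound 2. Compound 4 is therefore expected to give about 0.25 h in this assay, between 0.13 h and 0.5 h, with a 1.2-fold lower number from compound 2 to compound 4 (0.09 log units; within the scatter) expected to stay within the scatter.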

Compound 4, half-life: 0.163 h
For compound 4 the middle estimate is 1.5-fold (0.19 log units) above the measured one; the measured number falls inside the stated range.
By their numbers in this assay, from the lowest: compounds 4, 3, 1 and 2 (each within the scatter of the next).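

In this assay, chloro in place of trifluoromethyl at this place, on an aromatic carbon ortho to a large group, now has a direct reading (a 1.9-fold lower number from compound 2 to compound 4 (0.27 log units; within the scatter)). Together with the swap of the same pair of groups at the other position of the benzyl ring (a 1.3-fold lower number from compound 1 to compound 3 (0.11 log units; within the scatter)), this shows the exchange staying within the scatter in both settings, and in opposite directions of exchange. Among these compounds, the new compound also gives a first reading for methyl in place of hydrogen on an aromatic carbon of the core (a 1.4-fold lower number from compound 1 to compound 4 (0.14 log units; within the scatter)), again within the scatter. Nothing measured here explains these numbers. On these data alone, whether a nitrile, a methoxy group or a carboxylic acid on the benzyl ring would take the half-life beyond the scatter stays open, as does the effect of an amine in that place.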